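Swapping the amide substituent on a shared core

The source may hold more compounds than are shown below. What is called first, only, known or untested is meant among the compounds shown, and "the series" means these compounds.

Compounds measured in an assay on HL-60 cells for agonist activity at vitamin D3 receptor (Homo sapiens), read by microscopy, with a stated time of 96 h (on this read-out lower numbers stand for an effect already at smaller amounts and higher numbers for an effect only at larger amounts of compound), so far:
compound 1, `CC[C@@H](C)[C@H](NC(=O)c1ccc(C(CC)(CC)c2ccc(OCC(=O)C(C)(C)C)c(C)c2)n1CC)C(=O)OC`, gives 590 nM
compound 2, `CCN(CC)CCNC(=O)c1ccc(C(CC)(CC)c2ccc(OCC(=O)C(C)(C)C)c(C)c2)n1CC`, gives 91 nM
compound 3, `CCn1c(C(=O)NCC(OC)OC)ccc1C(CC)(CC)c1ccc(OCC(=O)C(C)(C)C)c(C)c1`, gives 130 nM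

All three compounds share one core and differ only in the group attached to the amide nitrogen. Compound 3 stands second highest of the three numbers: its nearest neighbour is compound 2, and the gap a 1.4-fold higher number from compound 2 to compound 3 (0.15 log units; within the scatter) lies within the usual scatter, so the two cannot be told apart. Its furthest neighbour is compound 1, and the step of a 4.5-fold lower number from compound 1 to compound 3 (0.66 log units; beyond the scatter) is clear. The step of a 6.5-fold lower number from compound 1 to compound 2 (0.81 log units; beyond the scatter) points the same way.

Compound 4, `C=CCN(C)C(=O)c1ccc(C(CC)(CC)c2ccc(OCC(=O)C(C)(C)C)c(C)c2)n1CC`, has not yet been measured. It differs from compound 3 in one place: allyl(methyl)amino in place of (2,2-dimethoxyethyl)amino on a carbonyl carbon. The incoming group carries no hydrogen-bond donor and no acceptor, and the nitrogen now bears two carbon substituents rather than one and a hydrogen.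

Two of the measured steps bear on this: replacing the large ester-bearing substituent of compound 1 with a smaller chain lowered the number in both cases, while the two smaller chains in compound 2 and compound 3 gave numbers within scatter of each other. Going by the values given here, that suggests this position tolerates varied small groups, though no measured compound lacks the amide hydrogen. For compound 4 in this assay the expected step is a 1.2-fold higher number from compound 3 to compound 4 (0.06 log units; within the scatter), that is, no change beyond the scatter. The estimate for compound 4 is 150 nM, with a range from 50 nM to 500 nM.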

Compound 4, half-maximal effective concentration: 21600 nM
Beside the measured number, compound 4's estimate is 140-fold (2.16 log units) below it; measured number above the stated range.
By their numbers in this assay, from the lowest: compounds 2 and 3 (each within the scatter of the next); then compound 1; then compound 4.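

In this assay, going by these compounds alone, this position proves far less forgiving than the earlier compounds suggested: both a 170-fold higher number from compound 3 to compound 4 (2.22 log units; beyond the scatter) and a 240-fold higher number from compound 2 to compound 4 (2.38 log units; beyond the scatter) are large steps, and even the 1-(methoxycarbonyl)-2-methylbutyl group, the least favourable of the earlier substituents, compares well, with a 37-fold higher number from compound 1 to compound 4 (1.56 log units; beyond the scatter). So the three earlier groups, different as they are, all give far lower numbers than allyl(methyl)amino, and compound 4 is the only compound here whose amide nitrogen bears two carbon substituents and no hydrogen, which ties the sharp rise to this change in the shown set without proving what drives it. No measured evidence on these compounds gives a reason for the jump.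

Within the data shown here, the single change in compound 4 removes the amide hydrogen, adds a methyl group and brings in an allyl double bond all at once, so it remains open which of these matters. An allylamino group, which keeps the amide hydrogen, and a dimethylamino group, which lacks both that hydrogen and the double bond, would help to pull these apart.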